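Aryl swaps on the cytotoxicity read-out: toward compound 4

The source may report more compounds than this note shows. Statements on the series, on what has been measured and on what is new or still open speak of the compounds shown alone.

Three analogues share one core and differ only in the aryl group on the carbon with a double bond to nitrogen. Compound 1 `CS(=O)(=O)c1ccc(Cc2nnc3n2N=C(c2ccccc2)CS3)cc1` gives 55.5% in a functional assay on RAW264.7 cells (Mus musculus) for cytotoxicity, read by MTT assay, with a stated time of 48 h, tested at 100 uM; on this read-out higher numbers stand for a stronger effect at the one concentration tested and lower numbers for a weaker effect. Compound 2 `CS(=O)(=O)c1ccc(Cc2nnc3n2N=C(c2cc(Cl)sc2Cl)CS3)cc1` gives 47.3%, and the change a number 8.2 percentage points lower from compound 1 to compound 2 (within the scatter). Compound 3 `CS(=O)(=O)c1ccc(Cc2nnc3n2N=C(c2ccc(Cl)cc2Cl)CS3)cc1` gives 31%, the lowest of the three numbers; its nearest neighbour is compound 2, and the step of a number 16.3 percentage points lower from compound 2 to compound 3 (beyond the scatter), while a number 24.5 percentage points lower from compound 1 to compound 3 (beyond the scatter).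

Compound 4 `CS(=O)(=O)c1ccc(Cc2nnc3n2N=C(c2ccc(O)c(C(N)=O)c2)CS3)cc1` is not yet measured. Relative to compound 3 the change is 3-carbamoyl-4-hydroxyphenyl in place of 2,4-dichlorophenyl on a carbon with a double bond to nitrogen. Among the measured compounds shown here, the steps that bear on it are those in which 2,4-dichlorophenyl entered: a number 24.5 percentage points lower from compound 1 to compound 3 (beyond the scatter) and a number 16.3 percentage points lower from compound 2 to compound 3 (beyond the scatter), both modest falls. For the measured compounds named here, removing that group is therefore expected to move the number back upward, though the incoming 3-carbamoyl-4-hydroxyphenyl has no precedent, so the size is uncertain. The expected step is a number 14 percentage points higher from compound 3 to compound 4 (beyond the scatter). Compound 4 is estimated at 45%, within 20% to 70%.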

Compound 4, a percentage reported as activity, at one concentration (the size of the read-out at that concentration, not a potency): 37.1%
Beside the measured number, compound 4's estimate is 7.9 percentage points above it, within the range that was stated.
By their numbers in this assay, from the lowest: compounds 3 and 4 (each within the scatter of the next); then compounds 2 and 1 (each within the scatter of the next).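

In this assay, the 3-carbamoyl-4-hydroxyphenyl group, the first aryl here with hydrogen-bond donors and acceptors, replaces 2,4-dichlorophenyl with a change of a number 6.1 percentage points higher from compound 3 to compound 4 (within the scatter), so this swap leaves the read-out unresolved despite the very different substituents. Against the other two aryl groups the steps are a number 10.2 percentage points lower from compound 2 to compound 4 (beyond the scatter) and a number 18.4 percentage points lower from compound 1 to compound 4 (beyond the scatter), so compounds 3 and 4, the two substituted phenyl rings, both lie beyond the scatter from the unsubstituted phenyl of compound 1, while compound 2 does not. No measurement bearing on the reason for these steps is available.

Still open, from the compounds shown here alone, is whether the hydroxyl, the carbamoyl or the pair sets the level of compound 4. A carboxylic acid or an amine in place of the carbamoyl would test how far this position tolerates other groups.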